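N-Allylation of the Weakest Sulfonamide in the Series

The source may report more compounds than this note shows. Statements on the series, on what has been measured and on what is new or still open speak of the compounds shown alone.

Three compounds carry the same sulfonamide on a shared core. Compound 1 `CCOc1ccc(NS(=O)(=O)c2ccc(C)cc2)c2cn[nH]c12` is the weakest of the three in a functional assay on A2780 cells (Homo sapiens) for cytotoxicity, read by MTT assay, with a stated time of 72 h (a higher number here means a weaker inhibitor, a lower number a stronger inhibitor), giving 55100 nM. Compound 2 `CCOc1ccc(NS(=O)(=O)c2ccc(C)cc2)c2c(Br)n[nH]c12` gives 10500 nM, and compound 3 `Cc1ccc(S(=O)(=O)Nc2cccc3c2cnn3C)cc1` gives 6620 nM. Within the data shown here, the one measured single-point step, a 5.2-fold lower number from compound 1 to compound 2 (0.72 log units; beyond the scatter), concerns a substituent on an aromatic carbon and does not touch the ring nitrogen.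

Compound 4 `C=CCn1ncc2c(NS(=O)(=O)c3ccc(C)cc3)ccc(OCC)c21` differs from compound 1 by allyl in place of hydrogen on an aromatic nitrogen. Among the measured compounds shown here, no measured step addresses this nitrogen alone. Compound 3 differs from compound 1 in two places at once, one of them an alkyl group on the ring nitrogen, and its number is lower than that of compound 1; this is the only indication available that substitution at this nitrogen is tolerated. Given this and the width of the scatter, compound 4 is expected to show a modest drop, a 3.7-fold lower number from compound 1 to compound 4 (0.57 log units; beyond the scatter), toward 15000 nM, with a likely range from 4000 nM to 50000 nM; the value awaits measurement.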

Compound 4, half-maximal inhibitory concentration: 61600 nM
Compound 4: the middle estimate sits 4.1-fold (0.61 log units) below what was measured, and the stated range ends below it.
By their numbers in this assay, from the lowest: compounds 3 and 2 (each within the scatter of the next); then compounds 1 and 4 (each within the scatter of the next).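

Allyl in place of hydrogen on the aromatic nitrogen is the first change at this position that can be read alone, and in this assay it gives a 1.1-fold higher number from compound 1 to compound 4 (0.05 log units; within the scatter). Unlike the bromo change on the aromatic carbon, a 5.2-fold lower number from compound 1 to compound 2 (0.72 log units; beyond the scatter), this change leaves the number of the core of compound 1 within the scatter, so the hydrogen on this nitrogen can give way to allyl without a measurable shift in this read-out. No measurement shown here offers a reason for this flat step.

Going by these compounds, whether a longer chain, an amine or a carboxylic acid on this nitrogen would behave as allyl does remains open. Also open, on these data alone, is whether allyl at this position would leave the number of compound 2 unchanged.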